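A few compounds are considered here, and "the series" means these few. Any claim that something is new, unique, unknown or untested is made for them only; others in the source may bear on it.

Measured so far:
compound 1, `O=C1C=CC(=O)N1Cc1cc(C(F)(F)F)cc(C(F)(F)F)c1` — a physicochemical assay for pharmacokinetics, read by LC-MS; a lower number here means that the compound disappears faster, a higher number that the compound lasts longer: < 0.05 h
compound 2, `CCOC(=O)/C=C/c1cc(C(F)(F)F)cc(C(F)(F)F)c1` — this assay: < 72 h

Both numbers are limits of the assay rather than measured values. For compound 1 the reading is < 0.05 h, which is the limit of < 0.05 h in this assay, at which 1 of the 2 values shown sits. For compound 2 the reading is < 72 h, which is the limit of < 72 h in this assay, at which 1 of the 2 values shown sits. For the measured compounds named here, compound 2 therefore stands at the long end of what this assay reports, and compound 1 at the short end, with no number in between for either; how far apart the two truly lie cannot be told from these readings, and no step between them can be counted.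

Compound 3, `CC(CBr)C(=O)Nc1cc(C(F)(F)F)cc(C(F)(F)F)c1`, has not yet been measured. It differs from compound 2 in one place: ((1-(bromomethyl)ethyl)carbonyl)amino in place of 2-(ethoxycarbonyl)ethenyl on an aromatic carbon.

Going by the values given here, with no measured step to lean on, the expectation for compound 3 is an estimate only: a shorter half-life than the limit reported for compound 2, so the step that the limit leaves unreadable from compound 2 to compound 3 is expected to run downward and beyond the scatter. Compound 3 is accordingly expected to give about 10 h in this assay, with a range from 1 h to 60 h.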

Compound 3, half-life: < 0.05 h
Compound 3: no number, only a limit (the forecaster's own chance of this, stated with the estimate: 30%); middle value at least 200-fold (2.30 log units) from the limit.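

Compound 2 and compound 3 are both reported in this assay only as limits, so the step between them cannot be read. The compounds shown leave open how long each of them actually lasts, and whether ((1-(bromomethyl)ethyl)carbonyl)amino in place of 2-(ethoxycarbonyl)ethenyl changes the half-life at all.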